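Sulfonamide variation on a shared oxadiazole-amide series

The source may report more compounds than this note shows. Statements on the series, on what has been measured and on what is new or still open speak of the compounds shown alone.

Measured in a functional assay on MDA-MB-231 cells (Homo sapiens) for antiproliferative activity, read by MTT assay, with a stated time of 72 h; a higher number here means a weaker inhibitor, a lower number a stronger inhibitor:
compound 1 `O=C(Nc1ccc(-c2noc(-c3cccc(NS(=O)(=O)c4ccccc4)c3)n2)c(Cl)c1)c1cccnc1` gives > 10000 nM
compound 2 `NS(=O)(=O)c1ccc(S(=O)(=O)Nc2cccc(-c3nc(-c4ccc(NC(=O)c5cccnc5)cc4Cl)no3)c2)cc1` gives > 10000 nM
compound 3 `COc1cccc(S(=O)(=O)Nc2cccc(-c3nc(-c4ccc(NC(=O)c5cccnc5)cc4Cl)no3)c2)c1` gives > 10000 nM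

Each of these values is a limit of this assay, not a number; compound 3 therefore stands only on a limit, and the two other values shown are limits as well (the limit of > 10000 nM in this assay, at which 3 of the 3 values shown sit). The steps a step that the two limits leave unreadable from compound 1 to compound 2 and a step that the two limits leave unreadable from compound 1 to compound 3 cannot be sized, and the same holds for a step that the two limits leave unreadable from compound 2 to compound 3. Within the data shown here, nothing among the measured compounds separates the three sulfonyl substituents from one another in this assay.

Compound 4 `CCNC(=O)Nc1ccc(S(=O)(=O)Nc2cccc(-c3nc(-c4ccc(NC(=O)c5cccnc5)cc4Cl)no3)c2)cc1` differs from compound 3 by the change 4-((ethylcarbamoyl)amino)phenyl in place of 3-methoxyphenyl on a sulfonyl sulfur. Among the measured compounds shown here, the two measured steps that touch this sulfonyl substituent, from compound 1 to compound 2 and from compound 2 to compound 3, are both unreadable, so no size or direction can be taken from them; the only evidence is that every variation at this position so far has stayed at the limit (the limit of > 10000 nM in this assay, at which 3 of the 3 values shown sit).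

Compound 4 is accordingly expected to remain at or near the limit, estimated at 15000 nM with a range from 4000 nM to 60000 nM. The expected step is a step that the limit leaves unreadable from compound 3 to compound 4, which, measured against a limit, is not expected to be readable.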

Compound 4, half-maximal inhibitory concentration: 3100 nM
The estimate for compound 4 lay 4.8-fold (0.68 log units) above the measured number; the whole stated range lies above it.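

In this assay, the substituent on the sulfonyl sulfur whose other neighbour is the sulfonamide nitrogen now yields a readable number, and the position is no longer flat at the limit: 4-((ethylcarbamoyl)amino)phenyl in place of 3-methoxyphenyl gives an at least 3.2-fold lower number from compound 3 to compound 4 (0.50 log units; beyond the scatter). The (ethylcarbamoyl)amino group in place of sulfamoyl gives an at least 3.2-fold lower number from compound 2 to compound 4 (0.50 log units; beyond the scatter), and in place of hydrogen on an aromatic carbon it gives an at least 3.2-fold lower number from compound 1 to compound 4 (0.50 log units; beyond the scatter), so the gain holds against all three earlier substituents, though each step is only a lower bound on its true size. The steps among the three earlier compounds still cannot be read: the limit of > 10000 nM in this assay, at which 3 of the 4 values shown sit.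

With only compound 4 carrying this group, the compounds shown leave open whether the step depends on the ethyl chain or on the carbamoylamino unit itself, which a plain amine, an unsubstituted carbamoylamino group or a longer chain such as butyl on the same phenyl ring would help to separate. Also open, going by these compounds, is whether a carboxylic acid at that place on the ring would give a readable number.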